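Benzyloxy against dihydroxyphenoxy in a urea–thiourea pair

The compounds below may be only part of what the source reports. "The series", "measured", "known", "first", "only" and "open" are said of these compounds alone.

The study covers four compounds that share a sulfonamide-linked scaffold carrying a bis(trifluoromethyl)phenyl group. Compound 1 `O=S(=O)(NCCNC(=S)Nc1cc(C(F)(F)F)cc(C(F)(F)F)c1)c1ccc(-c2ccccc2OCc2ccccc2)s1` is a thiourea whose aromatic oxygen bears a benzyl group. In a functional assay on HeLa cells (Homo sapiens) for inhibition, read by CCK-8 assay, with a stated time of 48 h (on this read-out higher numbers stand for weaker inhibition and lower numbers for stronger inhibition), compound 1 gives 4700 nM. Compound 2 `O=S(=O)(NCCNC(=S)Nc1cc(C(F)(F)F)cc(C(F)(F)F)c1)c1ccc(-c2ccccc2Oc2ccc(O)c(O)c2)s1` keeps the thiourea but carries a 3,4-dihydroxyphenyl on that oxygen. In this assay compound 2 reaches only a limit of the assay, > 20000 nM. Compound 3 `O=C(NCCNS(=O)(=O)c1ccc(-c2ccccc2Oc2ccc(O)c(O)c2)s1)Nc1cc(C(F)(F)F)cc(C(F)(F)F)c1` carries the same 3,4-dihydroxyphenoxy group but has a urea in place of the thiourea; how the cores of compound 3 and compound 2 differ is not broken down here. In this assay compound 3 also reaches only a limit, > 20000 nM. Two of the three values shown sit at this limit (the limit of > 20000 nM in this assay, at which 2 of the 3 values shown sit).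

The measured step is benzyl in place of 3,4-dihydroxyphenyl on an oxygen on an aromatic ring, and it produced an at least 4.2-fold lower number from compound 2 to compound 1 (0.62 log units; beyond the scatter). The same change, at the same place, leads from compound 3 to compound 4 `O=C(NCCNS(=O)(=O)c1ccc(-c2ccccc2OCc2ccccc2)s1)Nc1cc(C(F)(F)F)cc(C(F)(F)F)c1`, the urea with a benzyloxy group: benzyl in place of 3,4-dihydroxyphenyl on an oxygen on an aromatic ring.

Since compound 3 starts from a limit, the size of the step cannot be fixed, but it is expected to follow the direction seen with compound 1 and compound 2, giving an expected at least 3.3-fold lower number from compound 3 to compound 4 (0.52 log units; beyond the scatter). Compound 4 is therefore estimated at 6000 nM in this assay, within an expected range from 2500 nM to 20000 nM.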

Compound 4, half-maximal inhibitory concentration: 13500 nM
Beside the measured number, compound 4's estimate is 2.3-fold (0.35 log units) below it; the measured number falls inside the stated range.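

On the core of compound 3, the change of benzyl in place of 3,4-dihydroxyphenyl on an oxygen on an aromatic ring gives an at least 1.4-fold lower number from compound 3 to compound 4 (0.17 log units; that floor lies within the scatter), which points the same way as the step on the core of compound 2 but does not by itself establish a change beyond the scatter. On these data alone, compound 3 stands at > 20000 nM, which is a limit of the assay, so the step from it is a floor and its true size remains unknown. The two cores therefore show that the direction seen on the first core is not contradicted on the second, but they do not show that the change carries over with the same size: the same change on two cores in this assay, an at least 4.2-fold lower number (0.62 log units; beyond the scatter) from compound 2 to compound 1 and an at least 1.4-fold lower number (0.17 log units; that floor lies within the scatter) from compound 3 to compound 4; the limit leaves it open whether they differ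

The compounds shown leave open which part of the change matters in this assay, since the two hydroxyl groups leave and the benzyl enters in a single step, and a plain phenyl or a 3,4-dihydroxybenzyl on that oxygen would be needed to pull these apart. How a methyl or a longer alkyl chain on that oxygen would read also remains open, as do the true numbers behind the values held at the limit: the limit of > 20000 nM in this assay, at which 2 of the 4 values shown sit.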